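Bromo to methyl on the compound 3 aryl group

The source may hold more compounds than are shown below. What is called first, only, known or untested is meant among the compounds shown, and "the series" means these compounds.

Measured so far in a functional assay on MCF7 cells (Homo sapiens) for cytotoxicity, read by sulforhodamine B assay, with a stated time of 24 h; a higher number here means a weaker inhibitor, a lower number a stronger inhibitor
- compound 1 `N#CCC(=O)N/N=C1\C(=O)Nc2ccc(S(=O)(=O)N3CCOCC3)cc21` gives 27700 nM
- compound 2 `N=c1oc2ccccc2cc1C(=O)N/N=C1\C(=O)Nc2ccc(S(=O)(=O)N3CCOCC3)cc21` gives 20800 nM
- compound 3 `O=C1Nc2ccc(S(=O)(=O)N3CCOCC3)cc2/C1=N/c1ccc(Br)cc1` gives 44800 nM

Compound 3 (44800 nM) lies within the scatter of compound 1 and beyond the scatter of compound 2, whose number is the lower of that pair. The next structure is compound 4 `Cc1ccc(/N=C2\C(=O)Nc3ccc(S(=O)(=O)N4CCOCC4)cc32)cc1`, which carries methyl in place of bromo on an aromatic carbon, para to a large group, the whole difference being methyl in place of bromo on an aromatic carbon and nothing more.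

The measured steps bear on this only loosely. They are a 1.3-fold lower number from compound 1 to compound 2 (0.12 log units; within the scatter) and a 1.6-fold higher number from compound 1 to compound 3 (0.21 log units; within the scatter) and both exchange a much larger part of the structure. Among the compounds with values here, neither step stands beyond the scatter, yet no measured pair isolates bromo or methyl at this place. No step beyond the scatter is therefore expected in this assay in either direction. The estimated step is a 1.2-fold lower number from compound 3 to compound 4 (0.07 log units; within the scatter) and it is expected to stay inside the scatter. The estimate for compound 4 is 38000 nM with an expected range from 19000 nM to 75000 nM as a working figure.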

Compound 4, half-maximal inhibitory concentration: 55900 nM
The estimate for compound 4 lay 1.5-fold (0.17 log units) below the measured number; the measured number falls inside the stated range.
By their numbers in this assay, from the lowest: compounds 2, 1, 3 and 4 (each within the scatter of the next, the first and the last beyond it).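

In this assay, within the data shown here, the exchange of bromo for methyl on an aromatic carbon, para to a large group, gives a 1.2-fold higher number from compound 3 to compound 4 (0.10 log units; within the scatter) and is the first measured pair that isolates this one place. Between 4-bromophenyl and 4-methylphenyl, each change of a single heavy atom with no hydrogen-bond donors or acceptors, this read-out therefore draws no distinction, which the earlier steps, all exchanging much larger parts of the structure, could not show. The larger exchange on the double-bonded nitrogen, 4-methylphenyl in place of ((cyanomethyl)carbonyl)amino, gives a 2.0-fold higher number from compound 1 to compound 4 (0.30 log units; within the scatter) and so also stays inside the scatter, and nothing measured here offers an explanation for either step.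

Going by these compounds, whether an amine, a carboxylic acid or a longer alkyl chain in place of methyl on this aromatic carbon would move the number beyond the scatter remains open. The compounds shown also leave open whether any change to the shared core, rather than to the group on the double-bonded nitrogen, would alter the number in this assay at all.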